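Replacing an aryl group by chloro on the shared core

The compounds below may be only part of what the source reports. "The series", "measured", "known", "first", "only" and "open" are said of these compounds alone.

Compound 2 `O=C(Nc1ccc2cccnc2c1)c1ccc(-c2ccccc2F)nc1` and compound 1 `O=C(Nc1ccc2cccnc2c1)c1ccc(-c2cccc(F)c2)nc1` share one core and differ only in where the fluorine sits on the pendant ring. In an in vitro functional assay on 1321-N1 cells for antagonist activity at transient receptor potential cation channel subfamily V member 1 (Homo sapiens), read by FLIPR and calcium flux (on this read-out lower numbers stand for lower potency and higher numbers for higher potency (the scale is a negative logarithm)), compound 1 gives 8.6, and compound 2 gives 8.7. Going by the values given here, the step of a number 0.10 log units higher from compound 1 to compound 2 (within the scatter) is the only measured step in this set, and compound 2 stands with the higher of the two numbers, though the gap to compound 1 lies within the scatter. Compound 3 `O=C(Nc1ccc2cccnc2c1)c1ccc(Cl)nc1` is not yet measured. It differs from compound 2 by chloro in place of 2-fluorophenyl on an aromatic carbon. Among the compounds with values here, no measured step bears directly on this change: the step from compound 1 to compound 2 only moves a fluorine within the same ring and left the number almost unchanged, so it says nothing about taking the whole ring away. With an entire six-membered ring removed and one atom left in its place, a loss of potency in this assay is expected for compound 3, as a step of a number 1.10 log units lower from compound 2 to compound 3 (beyond the scatter). Compound 3 is therefore estimated at 7.6, within a range from 6.7 to 8.5.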

Compound 3, negative logarithm of the antagonist equilibrium constant: < 6.7
Compound 3 gave a limit, no number (the forecaster's own chance of this, stated with the estimate: 15%); middle value at least 0.90 log units from the limit.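

The earlier pair, with 2-fluorophenyl and 3-fluorophenyl, spoke only to where the fluorine sits on the pendant ring; compound 3 shows that the ring itself matters at this aromatic carbon, next to the ring nitrogen and para to a large group. In this assay, chloro in place of 2-fluorophenyl gives a number at least 2.00 log units lower from compound 2 to compound 3 (beyond the scatter), and chloro in place of 3-fluorophenyl gives a number at least 1.90 log units lower from compound 1 to compound 3 (beyond the scatter). Compound 3 stands at a limit of the assay and not at a number, so both steps are bounds whose full size stays unknown: the limit of < 6.7 in this assay, at which 1 of the 3 values shown sits.

The compounds shown leave open whether this position needs an aromatic ring as such or merely more atoms than a chloro, a question that a methyl, a methoxy, an amine or a saturated cyclohexyl on the same carbon would begin to answer. Also open, from the compounds shown here alone, is whether the pendant ring needs its fluorine at all, which a plain phenyl on the shared core would test.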